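A few compounds are considered here, and "the series" means these few. Any claim that something is new, unique, unknown or untested is made for them only; others in the source may bear on it.

Measured in a functional assay on MOLT-4 cells (Homo sapiens) for cytotoxicity, read by MTT assay, with a stated time of 48 h; on this read-out lower numbers stand for stronger inhibition and higher numbers for weaker inhibition:
- compound 1 `CCNc1n[n+]([O-])c2ccccc2[n+]1[O-]`: 3300 nM
- compound 2 `[O-][n+]1nc(NC2CC2)[n+]([O-])c2ccccc21`: 1900 nM
- compound 3 `CCN(CC)c1n[n+]([O-])c2ccccc2[n+]1[O-]`: > 17600 nM (a limit of the assay, not a number)

For the measured compounds named here, compound 2 gives 1900 nM and cannot be separated from the only other numerical value: a 1.7-fold lower number from compound 1 to compound 2 (0.24 log units; within the scatter). Compound 4 `[O-][n+]1nc(Nc2ccccc2)[n+]([O-])c2ccccc21` has phenyl in place of cyclopropyl on a nitrogen on an aromatic ring. Going by the values given here, the closest precedent is that same swap of one group on this nitrogen, which stayed within the scatter. The larger at least 5.3-fold higher number from compound 1 to compound 3 (0.72 log units; beyond the scatter) comes from adding a second group on the nitrogen, and compound 4 has no such second group. Hence no step beyond the scatter is expected, and the expected step is a 1.1-fold higher number from compound 2 to compound 4 (0.02 log units; within the scatter). For compound 4 the estimated value is 2000 nM, with an expected range of 700 nM to 8000 nM.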

Compound 4, half-maximal inhibitory concentration: 1400 nM
Compound 4: the middle estimate sits 1.4-fold (0.15 log units) above what was measured, within the range that was stated.
By their numbers in this assay, from the lowest: compounds 4, 2 and 1 (each within the scatter of the next, the first and the last beyond it). At a limit, above all of these: compound 3.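

In this assay, an aromatic ring on this nitrogen is accepted just as the three-membered ring was: a 1.4-fold lower number from compound 2 to compound 4 (0.13 log units; within the scatter), so phenyl and cyclopropyl cannot be separated here. Among the compounds with a single group on this nitrogen, a 2.4-fold lower number from compound 1 to compound 4 (0.37 log units; beyond the scatter) is the only step that clears the scatter, and it is modest. Compound 2 remains inseparable from both of its neighbours in this short order.

Going by these compounds, whether an amine on the phenyl, or a longer chain in place of it, would hold these values stays open. Nothing at hand bears on a cause for these steps.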